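This account rests on a few compounds, and the source may have more. Where it says the series, first, only, none or still open, it means among the compounds named here.

Among the compounds with values here, in a functional assay on G55T2 cells (Homo sapiens) for antiproliferative activity, read by WST assay, with a stated time of 72 h (on this read-out higher numbers stand for weaker inhibition and lower numbers for stronger inhibition), compound 1 (`COc1cc(OC)cc(C(=O)N(CCC(=O)NCc2ccccc2)Cc2ccc(C(=O)NO)cc2)c1`) gives 14700 nM as the higher of the two numbers so far, and compound 2 (`CN(C)c1ccc(C(=O)N(CCC(=O)NCc2ccc(Cl)cc2)Cc2ccc(C(=O)NO)cc2)cc1`) gives 460 nM as the lower. Compound 3 (`Cc1ccc(C(=O)N(CCC(=O)NCc2ccccc2)Cc2ccc(C(=O)NO)cc2)cc1`) differs from compound 1 in one place: 4-methylphenyl in place of 3,5-dimethoxyphenyl on a carbonyl carbon with 4-methylphenyl in place of 3,5-dimethoxyphenyl on a carbonyl carbon. Within the data shown here, no measured pair shows this change alone, so any forecast is rough. In this assay a moderate fall toward stronger inhibition is expected, an estimated 4.9-fold lower number from compound 1 to compound 3 (0.69 log units; beyond the scatter) that would lie beyond the scatter. Compound 3 is estimated at 3000 nM with an expected range from 800 nM to 11000 nM overall.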

Compound 3, half-maximal inhibitory concentration: 690 nM
Estimate against measurement, compound 3: 4.3-fold (0.64 log units) above; the measured number lies below the stated range.
By their numbers in this assay, from the lowest: compounds 2 and 3 (each within the scatter of the next); then compound 1.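

In this assay, the group on the carbonyl carbon attached to the amide-type nitrogen has a large effect: replacing 3,5-dimethoxyphenyl with 4-methylphenyl gives (a 21-fold lower number from compound 1 to compound 3 (1.33 log units; beyond the scatter)). Within the data shown here, this is the first comparison here in which only one place changes. No measurement here says why. Among these compounds, the single step cannot separate losing the two methoxy groups from gaining the methyl group. Unsubstituted phenyl or 4-methoxyphenyl at this place could help tell those two parts apart.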